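Isopropylamino to Diethylamino on the Carbonyl Carbon

The source may report more compounds than this note shows. Statements on the series, on what has been measured and on what is new or still open speak of the compounds shown alone.

Compound 1 `CC1=C(C(=O)CC(C)C)C(c2ccco2)NC(=O)N1` gives 16% in an assay on membranes from CHO cells for displacement of a labelled ligand from adenosine receptor A1 (Homo sapiens), read by scintillation counting, with a stated time of 60 min, tested at 1 uM; a higher number here means more inhibition at the concentration tested (going by the name of the read-out), a lower number less inhibition.
Compound 2 `CC1=C(C(=O)NC(C)C)C(c2ccco2)NC(=O)N1` gives 3% in this assay.

Going by the values given here, compound 2 stands lowest of the two numbers measured so far; its nearest neighbour is compound 1, and the one measured step, a number 13 percentage points lower from compound 1 to compound 2 (beyond the scatter), separates them. Compound 3 `CCN(CC)C(=O)C1=C(C)NC(=O)NC1c1ccco1` has not yet been measured. It differs from compound 2 in one place: diethylamino in place of isopropylamino on a carbonyl carbon. Among the compounds with values here, the only step that bears on this change is the one from compound 1 to compound 2, which sits on the same carbonyl carbon but exchanged a different pair of groups, so it shows only that this spot can move the number modestly. With so little to go on, the step is expected to be small, about a number 5 percentage points higher from compound 2 to compound 3 (within the scatter), not beyond the scatter. Compound 3 is therefore estimated at 8%, within a range from 0% to 25%.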

Compound 3, a percentage reported as inhibition, at one concentration (the size of the read-out at that concentration, not a potency): 11%
The estimate for compound 3 lay 3 percentage points below the measured number, and the stated range covers the measured number.
By their numbers in this assay, from the lowest: compounds 2, 3 and 1 (each within the scatter of the next, the first and the last beyond it).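

In this assay, the hydrogen-bond donor of isopropylamino is absent from diethylamino, yet this swap on the carbonyl carbon stays within the scatter (a number 8 percentage points higher from compound 2 to compound 3 (within the scatter)). Diethylamino in place of isobutyl also stays within the scatter (a number 5 percentage points lower from compound 1 to compound 3 (within the scatter)), so compound 3 cannot be separated from either earlier compound, even though compound 1 and compound 2 lie beyond the scatter of each other. Nothing available here explains these numbers.

On these data alone, how a ring amine such as piperidine or morpholine, or a longer chain such as hexylamino, would read on this carbonyl carbon remains open. All three numbers also come from a single tested concentration, so they leave the potency of these compounds open.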